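Swapping furan for thiophene on a longer-chain amide

The source may report more compounds than this note shows. Statements on the series, on what has been measured and on what is new or still open speak of the compounds shown alone.

Compound 1 `CCCCCCCCCCCCNC(=O)[C@@H](NC(=O)c1ccco1)[C@@H](C)O`: 87500 nM
Compound 2 `CCCCCCCCCCCCNC(=O)[C@@H](NC(=O)c1cccs1)[C@@H](C)O`: 29200 nM
Compound 3 `CCCCCCCCCCCCCCNC(=O)[C@@H](NC(=O)c1ccco1)[C@@H](C)O`: 200000 nM

Of the compounds shown here, three have been tested in a functional assay on SW-620 cells (Homo sapiens) for cytotoxicity, read by MTT assay, with a stated time of 48 h; on this read-out higher numbers stand for weaker inhibition and lower numbers for stronger inhibition. Compound 1 gives 87500 nM, compound 2 gives 29200 nM and compound 3 gives 200000 nM in this assay.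

All three share one core and differ only at two places. Compound 2 differs from compound 1 by thiophen-2-yl in place of furan-2-yl on a carbonyl carbon, and that change made a 3.0-fold lower number from compound 1 to compound 2 (0.48 log units; beyond the scatter). Compound 3 differs from compound 1 by ethyl in place of hydrogen on a saturated chain carbon, ten or more bonds along the chain from an amide-type nitrogen, and that change made a 2.3-fold higher number from compound 1 to compound 3 (0.36 log units; beyond the scatter). Compound 3 thus carries the highest number of the three, a weaker inhibitor than either of the others.

Compound 4 `CCCCCCCCCCCCCCNC(=O)[C@@H](NC(=O)c1cccs1)[C@@H](C)O` has not yet been measured. It differs from compound 3 by thiophen-2-yl in place of furan-2-yl on a carbonyl carbon. Within the data shown here, this is the same change as the one from compound 1 to compound 2; the place of the change is the same word for word, only the surrounding core is the longer-chain core of compound 3. Because a 3.0-fold lower number from compound 1 to compound 2 (0.48 log units; beyond the scatter) was seen when the change was made on the core of compound 1, a step of similar size is expected here, which is a 3.0-fold lower number from compound 3 to compound 4 (0.47 log units; beyond the scatter). Compound 4 is therefore expected to give about 67000 nM in this assay, with a range from 30000 nM to 150000 nM. The range is kept wide: the expectation rests on a single earlier example of the change, and the starting number of compound 3 is already the weakest of the set.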

Compound 4, half-maximal inhibitory concentration: 78400 nM
Estimate against measurement, compound 4: 1.2-fold (0.07 log units) below; low and high end bracket the measured number.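

In this assay, putting thiophen-2-yl in place of furan-2-yl on the longer-chain core gave a 2.6-fold lower number from compound 3 to compound 4 (0.41 log units; beyond the scatter), and this step matches the one seen earlier on the shorter-chain core: the same change on two cores in this assay, a 3.0-fold lower number (0.48 log units; beyond the scatter) from compound 1 to compound 2 and a 2.6-fold lower number (0.41 log units; beyond the scatter) from compound 3 to compound 4, 1.2-fold (0.07 log units) apart, within the scatter of two such steps

The chain change reads the same way from the other side, giving a 2.7-fold higher number from compound 2 to compound 4 (0.43 log units; beyond the scatter), and this step matches the one between the two compounds that carry furan-2-yl: the same change on two cores in this assay, a 2.3-fold higher number (0.36 log units; beyond the scatter) from compound 1 to compound 3 and a 2.7-fold higher number (0.43 log units; beyond the scatter) from compound 2 to compound 4, 1.2-fold (0.07 log units) apart, within the scatter of two such steps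

Across these four compounds, then, each change moves the number by a similar amount whichever form of the other place is present, but this rests on only two examples of each change in a single assay, so it neither shows why the number moves nor that the same step would appear on a different core.

The compounds shown leave open whether a chain shorter or longer than those here would keep these steps, and whether a phenyl ring in place of furan-2-yl or thiophen-2-yl would fit the same picture. Also open, going by these compounds, is what a methoxy group in place of the hydroxyl group of the shared core would do to the number and to these steps.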